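The source may report more compounds than this note shows. Statements on the series, on what has been measured and on what is new or still open speak of the compounds shown alone.

Compound 1 (`CC(=O)N1CCN(c2cccc(-c3cc(-c4ccnn4C4CC4)c4c(N)ncnn34)c2)C(=O)C1(C)C`) gives 36 nm/s
Compound 2 (`CC(=O)N1CCN(c2cc(-c3cc(Cl)c4c(N)ncnn34)ccc2Cl)C(=O)C1(C)C`) gives "not determined" (no result reported)

In an ADME assay on Caco-2 cells (Homo sapiens) for permeability, in the apical to basolateral direction (a higher number here means that the compound crosses the layer faster, a lower number that the compound crosses the layer more slowly), compound 2 stands without a number: its entry reads ("not determined" (no result reported)), so it cannot be ranked against compound 1, whose value is the only figure available (36 nm/s). Compound 3 (`CC(=O)N1CCN(c2cc(-c3cc(Cl)c4c(N)ncnn34)ccc2C#N)C(=O)C1(C)C`) has yet to be measured. The structural change is a small one (cyano in place of chloro on an aromatic carbon): cyano in place of chloro on an aromatic carbon, ortho to a large group and para to a large group.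

Among the measured compounds shown here, no measured step shows what such an exchange does in this assay, and compound 2 offers no starting figure. The expectation is therefore modest: no step beyond the usual scatter, and no favoured direction. For the measured compounds named here, the only anchor is compound 1 (36 nm/s), which differs from compound 3 in more than one place, so the range has to stay wide. For compound 3 the estimated value is (40 nm/s), with the result expected to fall between (12 nm/s) and (130 nm/s).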

Compound 3, apparent permeability: 200 nm/s
Compound 3: the middle estimate sits 5.0-fold (0.70 log units) below what was measured; measured number outside the range, above it.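

In this assay, among the compounds shown here, compound 3 gives (200 nm/s) while compound 2 gives ("not determined" (no result reported)), and with no number on one side, no step between compound 2 and compound 3 can be read. The compounds shown leave open what cyano in place of chloro does at this position in this read-out. No evidence on hand bears on the result of compound 3.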